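Aryl amide swap and tolerated concentration in the series

The source may hold more compounds than are shown below. What is called first, only, known or untested is meant among the compounds shown, and "the series" means these compounds.

Going by the values given here, compound 1 `COc1ccc2c(=O)c(/C=C/C(=O)Nc3cccc(C)c3)coc2c1` gives 554000 nM in an ADME assay on HepG2 2.2.15 cells (Homo sapiens) for cytotoxicity, read by MTT assay, with stated times of 48 h and 9 days (a lower number here means that less compound is tolerated, a higher number that more compound is tolerated), the highest of the three numbers measured so far. Compound 2 `COc1ccc2c(=O)c(/C=C/C(=O)Nc3ccccc3)coc2c1` gives 523000 nM, and compound 3 `COc1ccc2c(=O)c(/C=C/C(=O)NCc3ccccc3F)coc2c1` gives 146000 nM. The step of a 1.1-fold lower number from compound 1 to compound 2 (0.03 log units; within the scatter) comes with hydrogen in place of methyl on an aromatic carbon, whereas the steps of a 3.8-fold lower number from compound 1 to compound 3 (0.58 log units; beyond the scatter) and a 3.6-fold lower number from compound 2 to compound 3 (0.55 log units; beyond the scatter) follow 2-fluorobenzyl in place of 3-methylphenyl or phenyl on the amide-type nitrogen. Compound 4 `COc1ccc(NC(=O)/C=C/c2coc3cc(OC)ccc3c2=O)cc1` is not yet measured; the change 4-methoxyphenyl in place of 3-methylphenyl on an amide-type nitrogen keeps a substituted phenyl on that nitrogen, so the step from compound 1 to compound 2 is the closer precedent, and no move beyond the scatter is expected. Compound 4 is therefore estimated at 500000 nM (range 230000 nM to 1000000 nM), an expected step of a 1.1-fold lower number from compound 1 to compound 4 (0.04 log units; within the scatter).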

Compound 4, half-maximal cytotoxic concentration: 718000 nM
Compound 4: the middle estimate sits 1.4-fold (0.16 log units) below what was measured; low and high end bracket the measured number.
By their numbers in this assay, from the lowest: compound 3; then compounds 2, 1 and 4 (each within the scatter of the next).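

On the amide-type nitrogen, 4-methoxyphenyl stays with the other phenyl groups: a 1.3-fold higher number from compound 1 to compound 4 (0.11 log units; within the scatter) and a 1.4-fold higher number from compound 2 to compound 4 (0.14 log units; within the scatter) both lie within the scatter, so methoxy in place of hydrogen on an aromatic carbon gives no readable change. Compound 3 remains apart, with a 4.9-fold higher number from compound 3 to compound 4 (0.69 log units; beyond the scatter) as the largest step in the series. Nothing measured here accounts for this.

Open, on these data alone, is whether the benzyl link or the fluorine carries that gap, and whether a phenyl bearing a carboxylic acid or a dimethylamino group would stay with compounds 1, 2 and 4.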